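This account rests on a few compounds, and the source may have more. Where it says the series, first, only, none or still open, it means among the compounds named here.

Compound 1 `Cc1ccc(CS/C(=C/c2cc(C)ccc2C)C(=O)c2ccc(Cl)cc2)cc1` and compound 2 `Cc1ccc(CS/C(=C/c2ccccc2F)C(=O)c2ccc(Cl)cc2)cc1` share one core, while compound 3 `Cc1ccc(S(=O)(=O)/C(=C/c2cc(C)ccc2C)C(=O)c2ccc(Cl)cc2)cc1` and compound 4 `Cc1ccc(S(=O)(=O)/C(=C/c2ccccc2F)C(=O)c2ccc(Cl)cc2)cc1` share another; the difference between the two cores is not broken down here. In a functional assay on DU-145 cells (Homo sapiens) for inhibition, read by trypan blue exclusion, with a stated time of 96 h (on this read-out lower numbers stand for stronger inhibition of growth and higher numbers for weaker inhibition of growth), compound 1 gives 10000 nM, and compound 2 gives 10000 nM. The change made between them, (2-fluorophenyl in place of 2,5-dimethylphenyl on a double-bonded chain carbon bound to a double-bonded chain carbon), therefore produced no change at the digits printed from compound 1 to compound 2 (within the scatter). Compound 3 gives 1000 nM in this assay, the lowest number among the three measured compounds. The same change is now made on the core of compound 3: 2-fluorophenyl in place of 2,5-dimethylphenyl on a double-bonded chain carbon bound to a double-bonded chain carbon. Going by the values given here, compound 4 is expected to show no change at the digits printed from compound 3 to compound 4 (within the scatter) in this assay because the same change on the first core gave no change at the digits printed from compound 1 to compound 2 (within the scatter). The estimate for compound 4 in this assay is accordingly 1000 nM, with an expected range from 400 nM to 2500 nM.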

Compound 4, concentration for 50% growth inhibition: 2500 nM
Beside the measured number, compound 4's estimate is 2.5-fold (0.40 log units) below it, within the range that was stated.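

In this assay, putting 2-fluorophenyl in place of 2,5-dimethylphenyl gave a 2.5-fold higher number from compound 3 to compound 4 (0.40 log units; beyond the scatter). Set beside the step on the other core, this result does not differ from it: the same change on two cores in this assay, no change at the digits printed (within the scatter) from compound 1 to compound 2 and a 2.5-fold higher number (0.40 log units; beyond the scatter) from compound 3 to compound 4, 2.5-fold (0.40 log units) apart, within the scatter of two such steps. Going by these compounds alone, the change thus carried from one core to the other within the scatter, but this rests on only two steps and does not show that it would carry to a further core.

The compounds shown leave open how a methoxy group or a nitrile in place of the fluorine of the 2-fluorophenyl would behave. They also leave open whether an amine at the same place would follow the same course on both cores.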